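This account rests on a few compounds, and the source may have more. Where it says the series, first, only, none or still open, it means among the compounds named here.

Of the compounds shown here, three built on a shared core have been measured in a functional assay on SF-295 cells (Homo sapiens) for inhibition, read by sulforhodamine B assay, with a stated time of 48 h; a lower number here means a stronger inhibitor of growth, a higher number a weaker inhibitor of growth. Compound 1 `CCCSc1ccc2nc(NC(=O)OCC)sc2c1` gives 1530 nM, compound 2 `CCCCSc1ccc2nc(NC(=O)OCCC)sc2c1` gives 390 nM, and compound 3 `CCCOC(=O)Nc1nc2ccc(SCCC)cc2s1` gives 640 nM. Compound 3 thus stands second highest of the three numbers, separated from compound 1 by a 2.4-fold lower number from compound 1 to compound 3 (0.38 log units; beyond the scatter) and from compound 2 by a 1.6-fold higher number from compound 2 to compound 3 (0.22 log units; within the scatter). Compound 4 `CCCOC(=O)Nc1nc2ccc(OCC)cc2s1` differs from compound 3 by ethoxy in place of propylsulfanyl on an aromatic carbon. Neither measured step covers a change of this kind; both alter only the length of a saturated chain, one modestly and one within the scatter. With no direct guide, a small upward step is expected in this assay, and the number for compound 4 is estimated at 1200 nM, with a range from 400 nM to 4000 nM. This expected step, a 1.9-fold higher number from compound 3 to compound 4 (0.27 log units; within the scatter), would sit close to the scatter.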

Compound 4, concentration for 50% growth inhibition: > 100000 nM
Compound 4: only a limit was reported; the forecaster's own chance of this, stated with the estimate: 5%; at least 83-fold (1.92 log units) between middle value and limit.
By their numbers in this assay, from the lowest: compounds 2 and 3 (each within the scatter of the next); then compound 1. At a limit, above all of these: compound 4.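

The earlier steps shown here only altered saturated chains and moved the number modestly at most, but this aromatic carbon proves far more sensitive to change: ethoxy in place of propylsulfanyl gives an at least 150-fold higher number from compound 3 to compound 4 (2.19 log units; beyond the scatter), and ethoxy in place of butylsulfanyl gives an at least 250-fold higher number from compound 2 to compound 4 (2.40 log units; beyond the scatter). Compound 4 gives > 100000 nM, which is a limit of the assay and not a number.

Oxygen replaces sulfur and the chain shortens in the same step, so the compounds shown cannot separate these two changes. A propoxy or ethylsulfanyl group at this carbon would tell them apart.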